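This account rests on a few compounds, and the source may have more. Where it says the series, first, only, none or still open, it means among the compounds named here.

Measured so far:
- compound 1 `N#CC1=C(N)N(c2ccc(S(N)(=O)=O)cc2)C2=C(C(=O)CCC2)C1c1ccc(O)cc1`: 90%
- compound 2 `COc1ccc2ccccc2c1C1C(C#N)=C(N)N(c2ccc(S(N)(=O)=O)cc2)C2=C1C(=O)CCC2`: 40%

In a functional assay on Ehrlich cells (Mus musculus) for antiproliferative activity, read by trypan blue exclusion, with a stated time of 2 h, tested at 10 ug/mL (on this read-out higher numbers stand for a stronger effect at the one concentration tested and lower numbers for a weaker effect), compound 1 gives 90% and stands highest of the two numbers; the nearest is compound 2, and the step of a number 50 percentage points lower from compound 1 to compound 2 (beyond the scatter) lies beyond the scatter. That single measured step replaces 4-hydroxyphenyl with 2-methoxynaphthalen-1-yl on a saturated ring carbon and is large.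

Compound 3 `COc1ccc(C2C(C#N)=C(N)N(c3ccc(S(N)(=O)=O)cc3)C3=C2C(=O)CCC3)c2ccccc12` is not yet measured. It differs from compound 1 as follows: 4-methoxynaphthalen-1-yl in place of 4-hydroxyphenyl on a saturated ring carbon. Among the measured compounds shown here, the change is of the same kind as the one measured step: 4-hydroxyphenyl leaves and a methoxynaphthalenyl group enters on the same saturated ring carbon, the methoxy group now sitting at the 4-position of the naphthalene instead of the 2-position. For the measured compounds named here, only the step of a number 50 percentage points lower from compound 1 to compound 2 (beyond the scatter) bears on this, and it was a large fall. A fall of similar size is therefore expected, so the step of a number 45 percentage points lower from compound 1 to compound 3 (beyond the scatter) is the estimate, with the direction downward. Compound 3 is expected to give about 45%, within a range from 20% to 75%.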

Compound 3, a percentage reported as activity, at one concentration (the size of the read-out at that concentration, not a potency): 10%
Compound 3: the middle estimate sits 35 percentage points above what was measured; measured number outside the range, below it.
By their numbers in this assay, from the lowest: compound 3; then compound 2; then compound 1.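

In this assay, 4-methoxynaphthalen-1-yl in place of 4-hydroxyphenyl on the saturated ring carbon gives a number 80 percentage points lower from compound 1 to compound 3 (beyond the scatter), so both methoxynaphthalenyl groups shown read lower than the 4-hydroxyphenyl group of compound 1, with no compound here going against that. Among the compounds shown here, the two naphthalene isomers are also not interchangeable at this carbon: 4-methoxynaphthalen-1-yl in place of 2-methoxynaphthalen-1-yl gives a number 30 percentage points lower from compound 2 to compound 3 (beyond the scatter), which shows that the placement of the methoxy group on the naphthalene alone shifts the read-out, something the single earlier step could not separate from the exchange of the whole aryl group. No measurement is available that accounts for this difference between the isomers or for the falls from compound 1.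

Going by these compounds, each exchange from compound 1 adds a second aromatic ring and replaces the hydroxy group with a methoxy group at once, so the share of each change in the falls remains open. On these data alone, a 4-methoxyphenyl group and a 4-hydroxynaphthalen-1-yl group on the same carbon would separate the two changes, while the response to an amine on the phenyl ring, as in 4-aminophenyl, also remains open.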